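Notes on the 4-methylphenyl to 4-nitrophenyl step

This account rests on a few compounds, and the source may have more. Where it says the series, first, only, none or still open, it means among the compounds named here.

In a functional assay on QGY-7703 cells (Homo sapiens) for cytotoxicity, read by MTT assay, with a stated time of 24 h (on this read-out higher numbers stand for weaker inhibition and lower numbers for stronger inhibition), compound 1 `O=C1/C(=C/c2cccnc2)CN(S(=O)(=O)c2ccccc2)C/C1=C\c1ccccc1F` gives 4800 nM, and compound 2 `Cc1ccc(S(=O)(=O)N2C/C(=C\c3cccnc3)C(=O)/C(=C/c3ccccc3F)C2)cc1` gives 9700 nM, the higher of the two numbers. Compound 3 `O=C1/C(=C/c2cccnc2)CN(S(=O)(=O)c2ccc([N+](=O)[O-])cc2)C/C1=C\c1ccccc1F` differs from compound 2 as follows: nitro in place of methyl on an aromatic carbon. For the measured compounds named here, only one measured step bears on this change, the modest 2.0-fold higher number from compound 1 to compound 2 (0.31 log units; beyond the scatter), and it involves methyl but not nitro. On that thin evidence, a similarly modest move towards the number of compound 1 is expected, giving an expected 1.6-fold lower number from compound 2 to compound 3 (0.21 log units; within the scatter). For compound 3 the estimated value is 6000 nM, with an expected range of 2500 nM to 14000 nM.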

Compound 3, half-maximal inhibitory concentration: 5600 nM
Compound 3: the middle estimate sits 1.1-fold (0.03 log units) above what was measured, and the stated range covers the measured number.
By their numbers in this assay, from the lowest: compounds 1, 3 and 2 (each within the scatter of the next, the first and the last beyond it).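

Nitro, on an aromatic carbon para to a large group, gives a 1.7-fold lower number from compound 2 to compound 3 (0.24 log units; within the scatter) and a 1.2-fold higher number from compound 1 to compound 3 (0.07 log units; within the scatter) in this assay and so cannot be told apart from either neighbour, although compound 1 and compound 2 are separated beyond the scatter. At this position, a group of three heavy atoms with two hydrogen-bond acceptors therefore gives a number that is not separable from those of the hydrogen and methyl compounds. No supporting measurement bears on this reading.

Going by these compounds, whether an amine or a carboxylic acid at this position would also stay within the scatter of compound 1 remains open.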